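This account rests on a few compounds, and the source may have more. Where it says the series, first, only, none or still open, it means among the compounds named here.

Values in a functional assay (aorta) for inhibition, with Rattus norvegicus as the target; a lower number here means a stronger inhibitor, a higher number a weaker inhibitor:

- Compound 1 `CC(C)/N=C(\S)[C@]1(c2cccnc2)CCCC[S+]1[O-]`: 10000 nM
- Compound 2 `[O-][S+]1CCCC[C@]1(/C(S)=N/c1ccccc1)c1cccnc1`: > 30000 nM, a limit
- Compound 3 `O=C(O)CC/N=C(\S)[C@]1(c2cccnc2)CCCC[S+]1[O-]`: > 30000 nM, a limit

Compound 1 is the only one of these with an actual number. Compound 2 and compound 3 both sit at the limit of > 30000 nM in this assay, at which 2 of the 3 values shown sit.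

Compound 4 `C/N=C(\SC)[C@]1(c2cccnc2)CCCC[S+]1[O-]` carries a new group on a saturated ring carbon: a group of 5 heavy atoms (3 carbon, 1 nitrogen, 1 sulfur; no ring) in place of a group of 6 heavy atoms (4 carbon, 1 nitrogen, 1 sulfur; no ring), on a saturated ring carbon. Two measured steps change the group on the double-bonded nitrogen, and they bear on this only in part. Phenyl in place of isopropyl gave an at least 3.0-fold higher number from compound 1 to compound 2 (0.47 log units; beyond the scatter). 2-Carboxyethyl in place of isopropyl gave an at least 3.0-fold higher number from compound 1 to compound 3 (0.47 log units; beyond the scatter). For the measured compounds named here, no measured step removes the hydrogen-bond donor.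

Both departures from compound 1 raised the number, so a rise is expected here too, in the size of a 2.0-fold higher number from compound 1 to compound 4 (0.30 log units; within the scatter). Compound 4 is estimated at 20000 nM, with an expected range of 5000 nM to 60000 nM.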

Compound 4, concentration for 90% inhibition: > 30000 nM
Compound 4 ended at the assay's limit; the forecaster's own chance of this, stated with the estimate: 50%; middle value at least 1.5-fold (0.17 log units) from the limit.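

In this assay, earlier steps changed only the group on the double-bonded nitrogen, whereas here the whole group on the saturated ring carbon changes, going from 1 hydrogen-bond donor to 0 and giving an at least 3.0-fold higher number from compound 1 to compound 4 (0.47 log units; beyond the scatter). Compound 4 gives > 30000 nM, which is a limit. Compound 1 therefore remains the only compound with an actual number: the limit of > 30000 nM in this assay, at which 3 of the 4 values shown sit.

The new group differs at both the nitrogen and the sulfur, so the two changes cannot be separated. As far as these compounds go, whether a cyclohexyl group on the double-bonded nitrogen, with the donor kept, would give a lower number than compound 1 stays open.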